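The source may report more compounds than this note shows. Statements on the series, on what has been measured and on what is new or still open speak of the compounds shown alone.

Compound 1 `C=C(CC)C(=O)c1ccc(OCC(=O)Nc2ccc(C(=O)OC)cc2)c(Cl)c1Cl`: 4100 nM
Compound 2 `C=C(CC)C(=O)c1ccc(OCC(=O)Nc2ccc(O)c(Cl)c2)c(Cl)c1Cl`: 5500 nM
Compound 3 `C=C(CC)C(=O)c1ccc(OCC(=O)Nc2ccc(/C=C/C(=O)OCC)cc2)c(Cl)c1Cl`: 1700 nM

All three share one core and differ only in the group carried on the aromatic ring of the amide. In a functional assay on CLL cells (Homo sapiens) for cytotoxicity, read by MTT assay, with a stated time of 48 h (a higher number here means that more compound is needed for the effect, a lower number that less compound is needed), compound 3 gives the lowest number of the three, with compound 1 nearest and compound 2 furthest from it. Among the compounds with values here, the only measured step that bears on the next change is a 2.4-fold lower number from compound 1 to compound 3 (0.38 log units; beyond the scatter), a modest shift between two ester-bearing groups.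

Compound 4 `C=C(CC)C(=O)c1ccc(OCC(=O)Nc2ccc(C#N)cc2)c(Cl)c1Cl` differs from compound 3 in one place: cyano in place of 2-(ethoxycarbonyl)ethenyl on an aromatic carbon. Within the data shown here, no measured compound carries a cyano group, so the direction of this step rests on little, and a small loss is the cautious expectation. Compound 4 is expected to give about 3000 nM, within a range of 1200 nM to 7500 nM. This estimate means a step of a 1.8-fold higher number from compound 3 to compound 4 (0.25 log units; within the scatter), landing near the number seen for compound 1.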

Compound 4, half-maximal effective concentration: 7800 nM
Estimate against measurement, compound 4: 2.6-fold (0.41 log units) below; the whole stated range lies below it.
By their numbers in this assay, from the lowest: compound 3; then compounds 1, 2 and 4 (each within the scatter of the next).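

In this assay, putting cyano in place of 2-(ethoxycarbonyl)ethenyl on this aromatic carbon has a clear cost (a 4.6-fold higher number from compound 3 to compound 4 (0.66 log units; beyond the scatter)). Yet cyano does not separate from methoxycarbonyl (a 1.9-fold higher number from compound 1 to compound 4 (0.28 log units; within the scatter)), nor 4-cyanophenyl from 3-chloro-4-hydroxyphenyl (a 1.4-fold higher number from compound 2 to compound 4 (0.15 log units; within the scatter)), so among these changes only the step away from compound 3 is beyond the scatter. No measurement here explains this difference. Still open, as far as these compounds go, is whether the double bond or the ethyl ester of compound 3 matters more. From the compounds shown here alone, how a carboxylic acid or an amine would behave at this position is also open.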